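Cutting Back the Long Chain of Compound 2

The compounds below may be only part of what the source reports. "The series", "measured", "known", "first", "only" and "open" are said of these compounds alone.

In a functional assay on MCF7 cells (Homo sapiens) for antiproliferative activity, read by MTT assay, with a stated time of 72 h (a higher number here means a weaker inhibitor, a lower number a stronger inhibitor), compound 1 (`CCCCCCCCCCCNC[C@@H]1OC[C@H](N)[C@@H]1O`) reads 6770 nM and compound 2 (`CCCCCCCCCCCCNC[C@@H]1OC[C@H](N)[C@H]1O`) reads 12600 nM as its half-maximal inhibitory concentration. These two numbers lie within the usual scatter of each other, so compound 2 stands level with compound 1 on the evidence so far. The two compounds differ in more than one place, which leaves no clean single-change comparison to learn from.

Compound 3 (`CCCCCCCCCNC[C@@H]1OC[C@H](N)[C@H]1O`) awaits measurement. It arises from compound 2 through one change (hydrogen in place of propyl on a saturated chain carbon, nine bonds along the chain from an amine nitrogen) that puts hydrogen in place of propyl on a saturated chain carbon, nine bonds along the chain from an amine nitrogen. For the measured compounds named here, with no measured precedent, any forecast is tentative. The estimated step is a 2.2-fold higher number from compound 2 to compound 3 (0.35 log units; beyond the scatter) towards a weaker inhibitor, a modest expected loss. For compound 3 the expected value is 28000 nM with an estimated range from 10000 nM to 80000 nM in this measurement.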

Compound 3, half-maximal inhibitory concentration: 60300 nM
Estimate against measurement, compound 3: 2.2-fold (0.33 log units) below, and the stated range covers the measured number.
By their numbers in this assay, from the lowest: compounds 1 and 2 (each within the scatter of the next); then compound 3.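

For the compounds shown here, this is the first clean single-change comparison in the set: in this assay, putting hydrogen in place of propyl on a saturated chain carbon, nine bonds along the chain from an amine nitrogen, gives a 4.8-fold higher number from compound 2 to compound 3 (0.68 log units; beyond the scatter). The outer end of the chain is therefore not idle in this assay: losing those three carbons, with the shared core left as it was, is enough on its own to move the number beyond the scatter. No supporting measurement accounts for this loss.

Going by these compounds, one step cannot set a trend with chain length, so it remains open whether methyl or ethyl at this same place would recover part of the loss. On these data alone, it also remains open whether a longer chain than that of compound 2 would give a lower number or a higher one.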